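Aryl replacement on the shared core: compound 2 to compound 4

A few compounds are considered here, and "the series" means these few. Any claim that something is new, unique, unknown or untested is made for them only; others in the source may bear on it.

Values in a functional assay (muscle tissue) with Cavia porcellus as the target (on this read-out higher numbers stand for an effect only at larger amounts of compound and lower numbers for an effect already at smaller amounts), for the three measured compounds:
compound 1, `COC(=O)C1=C(C)N=C(C)/C(=C(/O)OC)C1c1c(F)cccc1Cl`: 7.59 nM
compound 2, `COC(=O)C1=C(C)N=C(C)/C(=C(\O)OC)C1c1ccc(Cl)cc1Cl`: 640 nM
compound 3, `COC(=O)C1=C(C)N=C(C)/C(=C(\O)OC)C1c1cccc([N+](=O)[O-])c1`: 3.98 nM

Compound 2 stands at the highest number of the three in this assay. Its nearest neighbour is compound 1, whose number lies far lower, beyond the scatter; compound 3 lies lower still, also beyond the scatter. Compound 2 is therefore the least active of the set on this read-out.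

The next compound, compound 4, is `COC(=O)C1=C(C)N=C(C)/C(=C(\O)OC)C1c1ccccc1Br`. It differs from compound 2 as follows: 2-bromophenyl in place of 2,4-dichlorophenyl on a saturated ring carbon. Among the measured compounds shown here, no measured pair of this kind exists in the set, so the size of the step is open. Both compound 1, at 7.59 nM, and compound 3, at 3.98 nM, carry a single six-membered aromatic ring on the same saturated ring carbon and sit far lower than compound 2, which suggests that compound 2 is the outlier and that a return toward lower numbers is the more likely direction; a step of roughly the size between compound 2 and compound 1 is expected, as a 32-fold lower number from compound 2 to compound 4 (1.51 log units; beyond the scatter). Compound 4 is accordingly estimated at 20 nM in this assay, within a range from 4 nM to 120 nM.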

Compound 4, half-maximal effective concentration: 7.59 nM
Compound 4: the middle estimate sits 2.6-fold (0.42 log units) above what was measured; the range from low to high includes it.
By their numbers in this assay, from the lowest: compounds 3, 1 and 4 (each within the scatter of the next); then compound 2.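

In this assay, the step (an 84-fold lower number from compound 2 to compound 4 (1.93 log units; beyond the scatter)) is the only one measured at this saturated ring carbon, and it is large even though the aryl group stays a single six-membered carbon-only aromatic ring with no hydrogen-bond donors or acceptors and no net charge on either side. Aromatic rings of this simple kind are thus not enough to decide the number here: the particular substitution on the ring matters, and 2,4-dichlorophenyl stands apart, while compound 4 falls within the scatter of compounds 1 and 3. Nothing available explains why this exchange carries so large a step.

The exchange changes both the halogen count and the halogen type at once, so the compounds shown cannot assign the step to the loss of one chlorine or to the arrival of bromine, and a phenyl carrying a single chlorine would be needed to separate the two. Also open, as far as these compounds go, is how this carbon responds to a non-aromatic cyclohexyl group, or to a phenyl bearing an amine or a carboxylic acid.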